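The compounds below may be only part of what the source reports. "The series", "measured", "known", "first", "only" and "open" are said of these compounds alone.

Notes on the series in an ADME assay on HT-29 cells (Homo sapiens) for cytotoxicity, read by MTT assay, with a stated time of 72 h; on this read-out lower numbers stand for stronger inhibition and higher numbers for weaker inhibition. Compound 1 `C=CCOc1cc(C2=C(c3cc(OC)c(OC)c(OC)c3)C(=O)C(O)C2)ccc1OC` gives > 100 ug/mL, a limit and not a number. Compound 2 `COc1cc(C2=C(c3cc(C)c(OC)c(C)c3)C(O)CC2=O)cc(OC)c1OC` gives > 100 ug/mL, also a limit. Compound 3 `COc1cc(C2=C(c3cc(C)c(OC)c(C)c3)C(OC(C)=O)CC2=O)cc(OC)c1OC` gives > 100 ug/mL, again a limit. The set therefore shares (the limit of > 100 ug/mL in this assay, at which 3 of the 3 values shown sit). Next comes compound 4 `COc1ccc(C2=C(c3cc(OC)c(OC)c(OC)c3)C(=O)CC2OC(C)=O)cc1NC=O`, with this change: 3-(formylamino)-4-methoxyphenyl in place of 4-methoxy-3,5-dimethylphenyl on a double-bonded ring carbon. Going by the values given here, the only measured step, a step that the two limits leave unreadable from compound 2 to compound 3, concerns the acetyl group and not this change, and it gives no size to carry over. The expected step, an at least 1.2-fold lower number from compound 3 to compound 4 (0.09 log units; that floor lies within the scatter), is none beyond the scatter, with no firm direction. For compound 4 the estimated value is 80 ug/mL, with an expected range of 15 ug/mL to 150 ug/mL.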

Compound 4, half-maximal inhibitory concentration: < 1 ug/mL
Compound 4 was reported as a limit; the forecaster's own chance of this, stated with the estimate: 60%; middle value at least 80-fold (1.90 log units) from the limit.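

In this assay, going by these compounds alone, 3-(formylamino)-4-methoxyphenyl in place of 4-methoxy-3,5-dimethylphenyl on a double-bonded ring carbon gives an at least 100-fold lower number from compound 3 to compound 4 (2.00 log units; beyond the scatter) and is the first readable step, since the acetyl step cannot be read. Compound 3 stands at a limit: the limit of > 100 ug/mL in this assay, at which 3 of the 4 values shown sit. Compound 4 also stands at a limit: the limit of < 1 ug/mL in this assay, at which 1 of the 4 values shown sits.

On these data alone, with both ends being limits, the full size of this step stays open. Also open, as far as these compounds go, is whether a free amine or an acetylamino group in place of the formylamino group would keep the low number.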